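Vinyl to prop-1-en-1-yl on Compound 3

This account rests on a few compounds, and the source may have more. Where it says the series, first, only, none or still open, it means among the compounds named here.

In a functional assay on A549 cells (Homo sapiens) for antiproliferative activity, read by MTT assay, with a stated time of 72 h (a higher number here means a weaker inhibitor, a lower number a stronger inhibitor), compound 3 `C=CC(=O)Nc1cccc(Oc2nc(Nc3ccc(OC)cc3)nc3c2CSCC3)c1` gives 4220 nM, the lower of two true numbers. Compound 1 `C/C=C/C(=O)Nc1cccc(Oc2nc(Nc3ccn(C)n3)nc3c2CSCC3)c1` reads > 50000 nM, which is a limit of the assay and not a number. Compound 2 `C/C=C/C(=O)Nc1cccc(Oc2nc(Nc3cccc(C#N)c3)nc3c2CSCC3)c1` carries prop-1-en-1-yl and a different group on a nitrogen on an aromatic ring, and gives 17200 nM. Compound 4 `C/C=C/C(=O)Nc1cccc(Oc2nc(Nc3ccc(OC)cc3)nc3c2CSCC3)c1` differs from compound 3 at one place: prop-1-en-1-yl in place of vinyl on a carbonyl carbon. Within the data shown here, the only measured step, an at least 2.9-fold lower number from compound 1 to compound 2 (0.46 log units; beyond the scatter), changes another group, so it bears only loosely on this swap. A modest rise in this assay is expected, namely a 1.9-fold higher number from compound 3 to compound 4 (0.28 log units; within the scatter). For compound 4 the estimated value is 8000 nM, with an expected range of 2500 nM to 25000 nM.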

Compound 4, half-maximal inhibitory concentration: 22200 nM
Estimate against measurement, compound 4: 2.8-fold (0.44 log units) below; the measured number falls inside the stated range.
By their numbers in this assay, from the lowest: compound 3; then compounds 2 and 4 (each within the scatter of the next). At a limit, above all of these: compound 1.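

Prop-1-en-1-yl in place of vinyl on a carbonyl carbon is the only change in a 5.3-fold higher number from compound 3 to compound 4 (0.72 log units; beyond the scatter) in this assay and so shows that this position is sensitive to the swap. By contrast, with prop-1-en-1-yl kept, the change on the nitrogen in a 1.3-fold higher number from compound 2 to compound 4 (0.11 log units; within the scatter) stays within the scatter. Compound 1 stands at a limit and not a number, so an at least 2.2-fold lower number from compound 1 to compound 4 (0.35 log units; beyond the scatter) is only a bound: the limit of > 50000 nM in this assay, at which 1 of the 4 values shown sits.

On these data alone, whether vinyl would also give a lower number with 3-cyanophenyl or 1-methyl-1H-pyrazol-3-yl on the nitrogen stays open. So does the outcome of a longer chain or an amine at the carbonyl position.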